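The source may hold more compounds than are shown below. What is called first, only, known or untested is meant among the compounds shown, and "the series" means these compounds.

Measured so far in an ADME assay on cells (Hepatocyte, Rattus norvegicus) for pharmacokinetics, read by LC-MS, with a stated time of 90 min, tested at 1 uM (on this read-out lower numbers stand for slow clearance and higher numbers for fast clearance), all on the shared core:
- compound 1 `CC(C)OC(=O)Nc1c(N)nc(-c2nn(Cc3ccccc3F)c3ncccc23)nc1N` gives 15 mL/min/kg
- compound 2 `Nc1nc(-c2nn(Cc3ccccc3F)c3ncccc23)nc(N)c1NC(=O)OC1COC1` gives 1.67 mL/min/kg
- compound 3 `Nc1nc(-c2nn(Cc3ccccc3F)c3ncccc23)nc(N)c1NC(=O)OCC1CC1` gives 23.3 mL/min/kg

Compound 3 sits at the fast-clearance end of this small set, together with compound 1. The step of a 1.6-fold higher number from compound 1 to compound 3 (0.19 log units; within the scatter) stays within the scatter, whereas the step of a 14-fold higher number from compound 2 to compound 3 (1.14 log units; beyond the scatter) goes beyond it.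

Compound 4 `Nc1nc(-c2nn(Cc3ccccc3F)c3ncccc23)nc(N)c1N1C[C@@H](C(F)(F)F)OC1=O` differs from compound 3 in one place: 2-oxo-5-(trifluoromethyl)-1,3-oxazolidin-3-yl in place of (cyclopropylmethoxycarbonyl)amino on an aromatic carbon. Going by the values given here, the entering group is a five-membered non-aromatic ring with one defined stereocentre, and no measured compound carries it.

The measured steps therefore bear on this change only loosely, as each swaps only the group on the oxygen and leaves the link to the core intact. The step of a 9.0-fold lower number from compound 1 to compound 2 (0.95 log units; beyond the scatter) shows that a change there can move the number beyond the scatter, while the cyclopropylmethyl and isopropyl compounds stay level. With cyclopropylmethyl gone, as in compound 2 at 1.67 mL/min/kg, a lower number is expected, though the drop should be smaller than that seen with oxetan-3-yl. The expected step is a 2.9-fold lower number from compound 3 to compound 4 (0.46 log units; beyond the scatter). For compound 4 the estimated clearance is 8 mL/min/kg, with an expected range of 2 mL/min/kg to 25 mL/min/kg.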

Compound 4, clearance: 26.7 mL/min/kg
Compound 4: the middle estimate sits 3.3-fold (0.52 log units) below what was measured; the whole stated range lies below it.
By their numbers in this assay, from the lowest: compound 2; then compounds 1, 3 and 4 (each within the scatter of the next).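

In this assay, exchanging the whole (cyclopropylmethoxycarbonyl)amino group for the ring leaves the number level, with a 1.1-fold higher number from compound 3 to compound 4 (0.06 log units; within the scatter) and a 1.8-fold higher number from compound 1 to compound 4 (0.25 log units; within the scatter). This position therefore tolerates a change of the link to the core, including the loss of the hydrogen-bond donor on this group and the entry of three fluorine atoms, without any shift beyond the scatter; only compound 2 stands apart, with a 16-fold higher number from compound 2 to compound 4 (1.20 log units; beyond the scatter). No measurement at hand accounts for compound 4 standing level with compounds 1 and 3, or for the low number of compound 2.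

Open, on these data alone, is whether the 2-oxo-1,3-oxazolidin-3-yl ring without its trifluoromethyl group, or with the opposite configuration at its stereocentre, would stay level with compound 4 or move towards compound 2. Also open, as far as these compounds go, is whether the low number belongs to the oxetan-3-yl group as such, which an oxetan-3-yl amine or a morpholine ring on this aromatic carbon could test.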